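The source may hold more compounds than are shown below. What is called first, only, known or untested is meant among the compounds shown, and "the series" means these compounds.

Values in an ADME assay on L02 cells (Homo sapiens) for cytotoxicity, read by MTT assay, with a stated time of 24 h; a lower number here means a stronger inhibitor, a higher number a weaker inhibitor:
- compound 1 `COc1ccc(/C=C2\CN(C)C/C(=C\c3ccccc3F)C2=O)cc1OC`: 10500 nM
- compound 2 `COc1cc(/C=C2\CN(C)C/C(=C\c3ccccc3F)C2=O)cc(OC)c1`: 11900 nM
- compound 3 `CN1C/C(=C\c2ccc(C(F)(F)F)cc2)C(=O)/C(=C/c2ccccc2F)C1`: 18600 nM

Compound 2 lies within the usual scatter of both compound 1 and compound 3, so these numbers do not separate it from either. Compound 4 `COc1cc(/C=C2\CN(C)C/C(=C\c3ccc(Cl)cc3Cl)C2=O)cc(OC)c1` is not yet measured. It carries 2,4-dichlorophenyl in place of 2-fluorophenyl on a double-bonded chain carbon bound to a double-bonded ring carbon. Within the data shown here, all three measured compounds keep 2-fluorophenyl at that place, so the series offers no direct precedent for this change. The step expected in this assay is a 1.3-fold lower number from compound 2 to compound 4 (0.12 log units; within the scatter), which would stay within the scatter. The estimate for compound 4 is 9000 nM, with an expected range of 4000 nM to 20000 nM.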

Compound 4, half-maximal inhibitory concentration: 18800 nM
Estimate against measurement, compound 4: 2.1-fold (0.32 log units) below; measured number inside the range.
By their numbers in this assay, from the lowest: compounds 1, 2, 3 and 4 (each within the scatter of the next).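

In this assay, 2,4-dichlorophenyl in place of 2-fluorophenyl on a double-bonded chain carbon bound to a double-bonded ring carbon gives a 1.6-fold higher number from compound 2 to compound 4 (0.20 log units; within the scatter). Among these compounds, this is the first direct comparison at this position, and it does not separate the two groups. No measured property bears on this step. From the compounds shown here alone, whether an amine or a carboxylic acid on this phenyl ring would give a step beyond the scatter remains open. So does whether the same change on the core of compound 1 would give a similar step.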